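From hydroxy to propoxy on compound 3

The source may report more compounds than this note shows. Statements on the series, on what has been measured and on what is new or still open speak of the compounds shown alone.

In a functional assay on MDA-MB-231 cells (Homo sapiens) for cytotoxicity, read by MTT assay (a higher number here means a weaker inhibitor, a lower number a stronger inhibitor), compound 1 (`O=C1/C(=C/c2ccc([N+](=O)[O-])cc2)CCC/C1=C\c1cccc([N+](=O)[O-])c1`) gives 8.85 ug/mL and compound 2 (`COc1cc(/C=C2\CCC/C(=C\c3ccc([N+](=O)[O-])cc3)C2=O)ccc1O`) gives 13.1 ug/mL. The change between them is small: a 1.5-fold higher number from compound 1 to compound 2 (0.17 log units; within the scatter). Compound 3 (`COc1cc(/C=C2\CCC/C(=C\c3ccc([N+](=O)[O-])cc3)C2=O)cc(Br)c1O`) stands at > 100 ug/mL, which is a limit of the assay and not a number. It was reached by adding bromo, a change that gives an at least 7.6-fold higher number from compound 2 to compound 3 (0.88 log units; beyond the scatter).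

Compound 4 (`CCCOc1c(Br)cc(/C=C2\CCC/C(=C\c3ccc([N+](=O)[O-])cc3)C2=O)cc1OC`) has propyl in place of hydrogen on an oxygen on an aromatic ring, hydroxy to propoxy: propyl in place of hydrogen on an oxygen on an aromatic ring. Among the compounds with values here, no measured step changes this hydroxy, so neither step sizes the change directly. The nearest guide is an at least 7.6-fold higher number from compound 2 to compound 3 (0.88 log units; beyond the scatter), which shows that the bromo-bearing parent has already lost measurable potency in this assay. Compound 4 retains that bromo, so no recovery is assumed, and no step beyond the scatter is expected in either direction. The estimated change is a number no higher from compound 3 to compound 4 (the limit leaves the size open). For compound 4 the expected value is 100 ug/mL, with an estimated range of 30 ug/mL to 200 ug/mL.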

Compound 4, half-maximal inhibitory concentration: 4.01 ug/mL
Compound 4: middle estimate off by 25-fold (1.40 log units), on the high side; the measured number lies below the stated range.
By their numbers in this assay, from the lowest: compound 4; then compounds 1 and 2 (each within the scatter of the next). At a limit, above all of these: compound 3.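

With bromo kept, propyl in place of hydrogen on this oxygen gives an at least 24-fold lower number from compound 3 to compound 4 (1.39 log units; beyond the scatter). A free hydroxy at this position is therefore not required for a measured value in this assay when bromo is present, and the bromo alone does not fix the series at the top of the range. Compound 3 stands at a limit of the assay and not a number, so the size of this step is bounded on one side only: the limit of > 100 ug/mL in this assay, at which 1 of the 4 values shown sits.

Propyl is the only chain shown on this oxygen, so it remains open whether methyl, a longer chain such as hexyl, or a chain ending in an amine would follow compound 4. Also open, going by these compounds, is what propyl does on this oxygen in the absence of bromo.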